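Working notes: from compound 3 to compound 4

The source may hold more compounds than are shown below. What is called first, only, known or untested is meant among the compounds shown, and "the series" means these compounds.

Values in a functional assay on ECa-109 cells (Homo sapiens) for cytotoxicity, read by MTT assay, with a stated time of 72 h (a lower number here means a stronger inhibitor, a higher number a weaker inhibitor), so far
- compound 1 `CN(C)c1ccc(C=C2C(=O)N(c3ccc(Cl)cc3)N(c3ccc(Cl)cc3)C2=O)cc1`: > 128000 nM (a limit of the assay, not a number)
- compound 2 `COc1cccc(C=C2C(=O)N(c3ccc(Cl)cc3)N(c3ccc(Cl)cc3)C2=O)c1`: 29000 nM
- compound 3 `COc1cccc(C=C2C(=O)N(c3ccc(Cl)cc3)N(c3ccc(Cl)cc3)C2=O)c1OC`: 6800 nM

Going by the values given here, compound 3 holds the lowest number so far. The closest gap is a 4.3-fold lower number from compound 2 to compound 3 (0.63 log units; beyond the scatter), and the comparison with the limit gives an at least 18-fold lower number from compound 1 to compound 3 (1.27 log units; beyond the scatter).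

Compound 4 `O=C1C(=Cc2ccc(F)cc2F)C(=O)N(c2ccc(Cl)cc2)N1c1ccc(Cl)cc1` brings (2,4-difluorophenyl in place of 2,3-dimethoxyphenyl on a double-bonded chain carbon bound to a double-bonded ring carbon), with 2,4-difluorophenyl in place of 2,3-dimethoxyphenyl. Among the compounds with values here, both methoxy groups leave, and no measured compound carries fluorine. The closest guide is the single added methoxy in a 4.3-fold lower number from compound 2 to compound 3 (0.63 log units; beyond the scatter), while an at least 4.4-fold lower number from compound 1 to compound 2 (0.64 log units; beyond the scatter) shows that swaps at this place can move the number. A modest step to a higher number is expected in this assay, with the direction uncertain. The expected step is a 2.4-fold higher number from compound 3 to compound 4 (0.37 log units; beyond the scatter). Compound 4 is estimated at 16000 nM, with a range of 4000 nM to 64000 nM.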

Compound 4, half-maximal inhibitory concentration: 13100 nM
The estimate for compound 4 lay 1.2-fold (0.09 log units) above the measured number, within the range that was stated.
By their numbers in this assay, from the lowest: compounds 3 and 4 (each within the scatter of the next); then compound 2. At a limit, above all of these: compound 1.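

In this assay, 2,3-dimethoxyphenyl can give way to 2,4-difluorophenyl at this place without a step beyond the scatter (a 1.9-fold higher number from compound 3 to compound 4 (0.28 log units; within the scatter)), so neither methoxy group is needed to hold the number. The same 2,4-difluorophenyl also improves on 3-methoxyphenyl (a 2.2-fold lower number from compound 2 to compound 4 (0.35 log units; beyond the scatter)). The step from 4-(dimethylamino)phenyl (an at least 9.7-fold lower number from compound 1 to compound 4 (0.98 log units; beyond the scatter)) starts from a limit, not a number: (the limit of > 128000 nM in this assay, at which 1 of the 4 values shown sits).

From the compounds shown here alone, whether fluorine itself or its placing in 2,4-difluorophenyl carries this result stays open. So does the reading in this assay for a carboxylic acid or a nitrile on this ring.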